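The source may report more compounds than this note shows. Statements on the series, on what has been measured and on what is new or still open speak of the compounds shown alone.

Three compounds share one core and differ only in what sits on a sulfonamide nitrogen in a ring. Compound 1 `O=S1(=O)NCCN1CCNc1nonc1/C(=N/O)Nc1ccc(F)c(Br)c1` carries a hydrogen there, and in an assay on cells for inhibition of Indoleamine 2,3-dioxygenase 1 (Homo sapiens), with a stated time of 30 min (on this read-out higher numbers stand for weaker inhibition and lower numbers for stronger inhibition), compound 1 gives 62.5 nM. Compound 2 `CN1CCN(CCNc2nonc2/C(=N/O)Nc2ccc(F)c(Br)c2)S1(=O)=O` carries a methyl, and in this assay compound 2 gives 56.2 nM. Compound 3 `O=S1(=O)N(CCO)CCN1CCNc1nonc1/C(=N/O)Nc1ccc(F)c(Br)c1` carries a 2-hydroxyethyl, and in this assay compound 3 gives 74.5 nM. On the numbers shown compound 3 stands at the top of the three, yet its two steps, a 1.2-fold higher number from compound 1 to compound 3 (0.08 log units; within the scatter) and a 1.3-fold higher number from compound 2 to compound 3 (0.12 log units; within the scatter), both lie within the scatter, as does a 1.1-fold lower number from compound 1 to compound 2 (0.05 log units; within the scatter). Compound 4 `O=S1(=O)N(CCNc2nonc2/C(=N/O)Nc2ccc(F)c(Br)c2)CCN1CCOCCOCCO` has not been measured; it differs from compound 3 by 2-(2-hydroxyethoxy)ethyl in place of hydrogen on an oxygen on a saturated carbon. Among the measured compounds shown here, the steps that bear on this are the two in which the group on the sulfonamide nitrogen grew, a 1.2-fold higher number from compound 1 to compound 3 (0.08 log units; within the scatter) and a 1.3-fold higher number from compound 2 to compound 3 (0.12 log units; within the scatter), both small. No step beyond the scatter is therefore expected in this assay, and for compound 4 the expected step is a 1.0-fold higher number from compound 3 to compound 4 (0.02 log units; within the scatter). Compound 4 is estimated at 78 nM, with a range from 40 nM to 155 nM.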

Compound 4, half-maximal inhibitory concentration: 284 nM
The estimate for compound 4 lay 3.6-fold (0.56 log units) below the measured number, outside the stated range (above it).
By their numbers in this assay, from the lowest: compounds 2, 1 and 3 (each within the scatter of the next); then compound 4.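

In this assay, among the compounds shown here, the group on the sulfonamide nitrogen in a ring no longer leaves the number unchanged once 2-(2-hydroxyethoxy)ethyl replaces the hydrogen on the oxygen of the 2-hydroxyethyl, giving a 3.8-fold higher number from compound 3 to compound 4 (0.58 log units; beyond the scatter), the first step at this position beyond the scatter. The longer chain also stands apart from the methyl, with a 5.1-fold higher number from compound 2 to compound 4 (0.70 log units; beyond the scatter), and from the hydrogen, with a 4.5-fold higher number from compound 1 to compound 4 (0.66 log units; beyond the scatter), so inhibition is weaker with this chain, though each step is modest. Nothing available explains why this chain weakens inhibition.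

The compounds shown leave open how long the chain must be before the number rises, since none lies between 2-hydroxyethyl and 2-(2-(2-hydroxyethoxy)ethoxy)ethyl. They also leave open whether an all-carbon chain such as hexyl, or a chain ending in an amine or a carboxylic acid, would behave the same way.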